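This account rests on a few compounds, and the source may have more. Where it says the series, first, only, none or still open, it means among the compounds named here.

Measured so far in a functional assay on Bel-7402 cells (Homo sapiens) for inhibition, read by MTT assay, with a stated time of 24 h, tested at 1 ug/mL; on this read-out lower numbers stand for less inhibition of growth and higher numbers for more inhibition of growth at the one concentration tested:

- compound 1 `O=C(O)CCCCC(CCSC(=O)c1ccccc1)SC(=O)c1ccccc1`: "not active" (no number reported)
- compound 2 `O=C(CCCCC(S)CCS)Nc1ccc([N+](=O)[O-])c(C(F)(F)F)c1`: 0.68%
- compound 3 `O=C(CCCCC(S)CCS)Nc1ccc(Cl)cn1`: 2.34%

In this assay, compound 1 is recorded as "not active" (no number reported). No number was reported for it, so it offers a qualitative reading but no numerical baseline. For the measured compounds named here, compound 2 at 0.68% and compound 3 at 2.34% supply the only numbers. These two values lie within the scatter of each other, and both sit near the bottom of the scale.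

The next compound to be measured is compound 4 `O=C(CCCCC(CCSC(=O)c1ccccc1)SC(=O)c1ccccc1)Nc1ccccc1`. It keeps the core of compound 1 and carries anilino in place of hydroxy on a carbonyl carbon. Going by the values given here, no measured pair isolates this change, so its size cannot be read directly from the data.

The expectation therefore rests on the reading of compound 1 as "not active" (no number reported) and on the low values of compound 2 and compound 3. No step beyond the scatter is expected in this assay, in either direction, although an increase in inhibition cannot be excluded.

Compound 4 is estimated at 4%, with an expected range from 0% to 18%.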

Compound 4, percent growth inhibition at one concentration: "not active" (no number reported)
Nothing numeric was reported for compound 4; there is nothing to compare the estimate with.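

In this assay compound 1 reads "not active" (no number reported) and compound 4 reads "not active" (no number reported) with no number for either, so no step can be read for anilino in place of hydroxy on a carbonyl carbon. The compounds shown leave open whether this change has any measurable size. Nothing available bears on an explanation of this result.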